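Replacing the fluorinated aryl on the urea of compound 3

This account rests on a few compounds, and the source may have more. Where it says the series, first, only, none or still open, it means among the compounds named here.

Three ureas sharing one core have been measured so far. Compound 1 `O=C(Nc1ccc(Oc2ccc(-c3nccs3)cc2)cc1)Nc1ccc(Cl)c([N+](=O)[O-])c1` gives 77.1% in a functional assay on A549 cells (Homo sapiens) for inhibition, read by MTT assay and WST assay, with a stated time of 72 h, tested at 10 uM; a higher number here means more inhibition of growth at the concentration tested, a lower number less inhibition of growth. Compound 2 `O=C(Nc1ccc(Oc2ccc(-c3nccs3)cc2)cc1)Nc1cccc(C(F)(F)F)c1` gives 71.5% in this assay, and compound 3 `O=C(Nc1ccc(Oc2ccc(-c3nccs3)cc2)cc1)Nc1ccc(F)c(C(F)(F)F)c1` gives 76.4% in this assay. Compound 3 stands second highest of the three; its nearest neighbour is compound 1, with a number 0.7 percentage points lower from compound 1 to compound 3 (within the scatter), and its furthest is compound 2, with a number 4.9 percentage points higher from compound 2 to compound 3 (within the scatter), so none of these steps exceeds the scatter.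

Compound 4 `Cc1ccc(NC(=O)Nc2ccc(Oc3ccc(-c4nccs4)cc3)cc2)cc1` is not yet measured. It differs from compound 3 by 4-methylphenyl in place of 4-fluoro-3-(trifluoromethyl)phenyl on an amide-type nitrogen. All three measured steps concern this same aryl group on the urea nitrogen: a number 5.6 percentage points lower from compound 1 to compound 2 (within the scatter) exchanged the whole substituted ring, a number 0.7 percentage points lower from compound 1 to compound 3 (within the scatter) did so as well, and a number 4.9 percentage points higher from compound 2 to compound 3 (within the scatter) added a single fluoro. Each stayed within the scatter, which suggests that changes of this kind at this position move this assay little. Compound 4 is therefore expected to lie close to compound 3, with a number 6.4 percentage points lower from compound 3 to compound 4 (within the scatter) as the estimated step. The estimate for compound 4 is 70%, with a range from 52% to 84%.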

Compound 4, percent growth inhibition at one concentration: 15.6%
Estimate against measurement, compound 4: 54.4 percentage points above; measured number outside the range, below it.
By their numbers in this assay, from the lowest: compound 4; then compounds 2, 3 and 1 (each within the scatter of the next).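

For the compounds shown here, the aryl group on this urea nitrogen proved far less forgiving than the earlier compounds suggested: in this assay there is a number 60.8 percentage points lower from compound 3 to compound 4 (beyond the scatter), alongside a number 55.9 percentage points lower from compound 2 to compound 4 (beyond the scatter) and a number 61.5 percentage points lower from compound 1 to compound 4 (beyond the scatter), while the three earlier aryl groups stay within the scatter of one another. Among these four compounds, the number therefore separates into two levels, with no intermediate compound: compounds 1, 2 and 3 form a high group, and compound 4 stands alone far beneath it. The 4-methylphenyl of compound 4 is also the only one of the four aryl groups with no fluoro, chloro, trifluoromethyl or nitro substituent, but nothing available explains why this exchange has so large an effect.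

From the compounds shown here alone, what remains open is whether the methyl group itself lowers the number or whether the loss reflects only the absence of the groups it replaces, a question that a plain phenyl on this nitrogen would help to settle. Going by these compounds, it is also open how this assay would respond to an aryl group bearing a nitrile or an amine.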